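A few compounds are considered here, and "the series" means these few. Any claim that something is new, unique, unknown or untested is made for them only; others in the source may bear on it.

Among the three compounds measured so far in a functional assay on B16-F10 cells (Mus musculus) for antiproliferative activity, read by ELISA and MTT assay, with a stated time of 48 h (on this read-out lower numbers stand for stronger inhibition and higher numbers for weaker inhibition), compound 1 `O=C(/C=C/c1ccccc1)NS(=O)(=O)c1ccc(Cl)cc1` gives the lowest number, 2.2 ug/mL. Compound 2 `O=C(/C=C/c1ccccc1)NS(=O)(=O)c1ccc(Br)cc1` gives 3.9 ug/mL, and the change from compound 1 to compound 2, a 1.8-fold higher number from compound 1 to compound 2 (0.25 log units; within the scatter), falls within the scatter. Compound 3 `COc1ccc(/C=C/C(=O)NS(=O)(=O)c2ccc(Cl)cc2)cc1` gives 5.3 ug/mL, and here the step of a 2.4-fold higher number from compound 1 to compound 3 (0.38 log units; beyond the scatter) lies beyond the scatter, though it is modest.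

Compound 4 `O=C(/C=C/c1ccccc1[N+](=O)[O-])NS(=O)(=O)c1ccc(Cl)cc1` has not yet been measured. It differs from compound 1 in one place: nitro in place of hydrogen on an aromatic carbon, on an aromatic carbon of a six-membered aromatic ring of carbon only, ortho to a large group. Among the measured compounds shown here, no measured step introduces a nitro group, so the only guide is compound 3, where a methoxy entering on the same aromatic ring raised the number by a 2.4-fold higher number from compound 1 to compound 3 (0.38 log units; beyond the scatter). On that basis compound 4 is expected to sit near compound 1 or somewhat higher, a step of a 1.6-fold higher number from compound 1 to compound 4 (0.20 log units; within the scatter) that may not clear the scatter. The estimate for compound 4 in this assay is 3.5 ug/mL, with a range from 1.5 ug/mL to 8 ug/mL.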

Compound 4, half-maximal inhibitory concentration: 6.6 ug/mL
Beside the measured number, compound 4's estimate is 1.9-fold (0.28 log units) below it, and the stated range covers the measured number.
By their numbers in this assay, from the lowest: compounds 1, 2, 3 and 4 (each within the scatter of the next, the first and the last beyond it).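

In this assay, a 3.0-fold higher number from compound 1 to compound 4 (0.48 log units; beyond the scatter), so a nitro group on this aromatic carbon, ortho to a large group, gives a modest step that lies beyond the scatter. Until this result, methoxy in compound 3 was the only group shown entering this ring; compound 4 adds a second, different group, and among these compounds both additions to the ring of compound 1 move the number in the same direction. Nothing available explains why the number rises with this change.

The compounds shown leave open whether an amine or a carboxylic acid in the same place would also raise the number. They also leave open whether a nitro group elsewhere on this ring would give a step of similar size.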